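The source may report more compounds than this note shows. Statements on the series, on what has been measured and on what is new or still open speak of the compounds shown alone.

Measured so far:
compound 1 `O=[N+]([O-])c1cc(Nc2nc3nonc3nc2O)ccc1OC(F)(F)F` gives 53500 nM
compound 2 `CCCCOc1ccc(Nc2nc3nonc3nc2O)cc1` gives 3700 nM

In an assay on mitochondria from L6 cells (Rattus norvegicus) for activation, with a stated time of 90 min (on this read-out lower numbers stand for an effect already at smaller amounts and higher numbers for an effect only at larger amounts of compound), compound 2 holds the lower of the two numbers; the gap up to compound 1 lies beyond the scatter, so compound 2 is the better of the pair in this assay.

Compound 3 `CCCCCCc1ccc(Nc2nc3nonc3nc2O)cc1` is the next step from compound 2: hexyl in place of butoxy on an aromatic carbon. Within the data shown here, no measured pair shows this change, so its size cannot be read from the data; in this assay the expectation is a step within the scatter, with no firm direction. Compound 3 is expected at 3000 nM, in the range 800 nM to 12000 nM. That estimate means an expected step of a 1.2-fold lower number from compound 2 to compound 3 (0.09 log units; within the scatter).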

Compound 3, half-maximal effective concentration: 4700 nM
Compound 3: middle estimate off by 1.6-fold (0.19 log units), on the low side; measured number inside the range.
By their numbers in this assay, from the lowest: compounds 2 and 3 (each within the scatter of the next); then compound 1.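

In this assay, hexyl in place of butoxy on an aromatic carbon, para to a large group, gives a 1.3-fold higher number from compound 2 to compound 3 (0.10 log units; within the scatter) and leaves the two compounds unseparated. At this position, the oxygen of butoxy can therefore be lost and the chain changed to hexyl without a step beyond the scatter. No supporting measurement bears on this result.

Still open, from the compounds shown here alone, is how a longer chain than hexyl, or a shorter chain, would read at this place. An amine or a carboxylic acid on the chain end also remains untested among the compounds shown.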